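Adding a methyl to the ethylamino chain of compound 2

This account rests on a few compounds, and the source may have more. Where it says the series, first, only, none or still open, it means among the compounds named here.

Measured in a functional assay on K562 cells (Homo sapiens); on this read-out lower numbers stand for stronger inhibition and higher numbers for weaker inhibition:
Compound 1 `CCNC(=O)Nc1ccc(C(C)C)cc1` gives 142000 nM
Compound 2 `CCNC(=O)Nc1ccc(C(C)CC)cc1` gives 101000 nM
Compound 3 `CCNC(=O)Nc1ccc(C(C)(C)C)cc1` gives 84000 nM

Compound 2 is not separated from either of the other two compounds on these numbers. The record shows a 1.4-fold lower number from compound 1 to compound 2 (0.15 log units; within the scatter) and also a 1.2-fold lower number from compound 2 to compound 3 (0.08 log units; within the scatter), so the three values form one group.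

Compound 4 `CCCNC(=O)Nc1ccc(C(C)CC)cc1` is compound 2 with a single change, (methyl in place of hydrogen on a saturated chain carbon, two bonds along the chain from an amide-type nitrogen), which turns ethylamino into propylamino. For the measured compounds named here, no measured step makes this change at this place. The closest guides are two methyl additions elsewhere in the molecule, on the saturated chain at the aromatic carbon: a 1.4-fold lower number from compound 1 to compound 2 (0.15 log units; within the scatter) and a 1.7-fold lower number from compound 1 to compound 3 (0.23 log units; within the scatter). Neither leaves the scatter, so no step beyond the scatter is expected in this assay for the new methyl. The expected step is a 1.1-fold lower number from compound 2 to compound 4 (0.05 log units; within the scatter). Compound 4 is estimated at 90000 nM, with an expected range from 45000 nM to 170000 nM.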

Compound 4, half-maximal inhibitory concentration: 106000 nM
Compound 4: the middle estimate sits 1.2-fold (0.07 log units) below what was measured; the measured number falls inside the stated range.
By their numbers in this assay, from the lowest: compounds 3, 2, 4 and 1 (each within the scatter of the next).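

In this assay, the methyl added to the ethylamino chain gives a 1.0-fold higher number from compound 2 to compound 4 (0.02 log units; within the scatter), so turning ethylamino into propylamino does not separate compound 4 from compound 2 on this read-out. The earlier compounds shown here could not show this, as they differ only on the saturated chain at the aromatic carbon and leave the ethylamino chain untouched. A methyl addition can now be compared at both places, and the two steps do not differ beyond the scatter: the same change on two cores in this assay, a 1.7-fold lower number (0.23 log units; within the scatter) from compound 1 to compound 3 and a 1.0-fold higher number (0.02 log units; within the scatter) from compound 2 to compound 4, 1.8-fold (0.25 log units) apart, within the scatter of two such steps

The compounds shown leave open whether a longer chain such as butylamino, or an amine or a carboxylic acid carried on the propylamino chain, would move the number beyond the scatter. They also leave open whether the step seen here would hold for propylamino on the core of compound 1 or compound 3.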